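Imidazole replacement on the ether side chain in the dihydropyridine series

The compounds below may be only part of what the source reports. "The series", "measured", "known", "first", "only" and "open" are said of these compounds alone.

Compound 3 `CCO/C(O)=C1\C(COCCn2ccnc2C)=NC(C)=C(C(=O)OC)C1c1ccccc1Cl` gives 2.51 nM in a functional assay (aorta) with Rattus norvegicus as the target (on this read-out higher numbers stand for weaker inhibition and lower numbers for stronger inhibition), the lowest of the three measured numbers, though within the scatter of compound 1 `CCO/C(O)=C1\C(COCCn2ccnn2)=NC(C)=C(C(=O)OC)C1c1cccc(Cl)c1Cl`, which gives 5.01 nM, and of compound 2 `CCO/C(O)=C1\C(COCCn2c(C)nc(C)c2C)=NC(C)=C(C(=O)OC)C1c1ccccc1Cl`, which gives 5.01 nM. Among the compounds with values here, the one step that touches the same position, a 2.0-fold lower number from compound 2 to compound 3 (0.30 log units; within the scatter), stays within the scatter, so the ring on that chain carbon has so far been tolerant. Compound 4 `CCO/C(O)=C1\C(COCCN2CC(=O)N=C2N)=NC(C)=C(C(=O)OC)C1c1ccccc1Cl` carries the change (a group of 7 heavy atoms (3 carbon, 3 nitrogen, 1 oxygen; one five-membered non-aromatic ring with 2 hetero atoms) in place of a group of 6 heavy atoms (4 carbon, 2 nitrogen; one five-membered aromatic ring with 2 hetero atoms), on a saturated chain carbon, two bonds along the chain from an oxygen on a saturated carbon). Within the data shown here, only the step from compound 2 to compound 3 bears on this, and it was small, so a step not beyond the scatter is expected: a 1.6-fold higher number from compound 3 to compound 4 (0.20 log units; within the scatter). Compound 4 is therefore estimated at 4 nM in this assay, with a range of 1.3 nM to 13 nM.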

Compound 4, half-maximal inhibitory concentration: 20 nM
Estimate against measurement, compound 4: 5.0-fold (0.70 log units) below; measured number above the stated range.
By their numbers in this assay, from the lowest: compounds 3, 1 and 2 (each within the scatter of the next); then compound 4.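

In this assay, the tolerance seen among the aromatic rings on this saturated chain carbon does not extend to the five-membered non-aromatic ring: replacing 2-methyl-1H-imidazol-1-yl gives an 8.0-fold higher number from compound 3 to compound 4 (0.90 log units; beyond the scatter), and replacing 2,4,5-trimethyl-1H-imidazol-1-yl gives a 4.0-fold higher number from compound 2 to compound 4 (0.60 log units; beyond the scatter). Both steps lie beyond the scatter, so this position does respond to the nature of the ring. No supporting data bear on the reason for this loss.

Ring type, heavy-atom count and hydrogen-bond counts change together in these steps, so their separate contributions remain open. Going by these compounds, how a morpholine or a carboxylic acid at this chain carbon would read also remains open.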